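Isothiocyanate chain shortened on the shared core

The source may hold more compounds than are shown below. What is called first, only, known or untested is meant among the compounds shown, and "the series" means these compounds.

Among the measured compounds shown here, compound 2 `CN(C)C(=O)c1cc2cnc(Nc3ccc(NC(=O)CCCN=C=S)cc3)nc2n1C1CCCC1` stands highest of the two numbers so far in a functional assay on A549 cells (Homo sapiens) for inhibition, read by CCK-8 assay, with a stated time of 72 h, tested at 1 uM (on this read-out lower numbers stand for a weaker effect and higher numbers for a stronger effect at the one concentration tested), where compound 2 gives 56.1%; compound 1 `CN(C)C(=O)c1cc2cnc(Nc3ccc(C(=O)NCCCCCCN=C=S)cc3)nc2n1C1CCCC1` gives 35.8% in this assay. For the measured compounds named here, the one measured step, a number 20.3 percentage points higher from compound 1 to compound 2 (beyond the scatter), accompanied a shorter chain bearing the isothiocyanate. Compound 3 `CN(C)C(=O)c1cc2cnc(Nc3ccc(N=C=S)cc3)nc2n1C1CCCC1` carries the change (a group of 3 heavy atoms (1 carbon, 1 nitrogen, 1 sulfur; no ring) in place of a group of 9 heavy atoms (5 carbon, 2 nitrogen, 1 oxygen, 1 sulfur; no ring), on an aromatic carbon), shortening the chain further. Going by the values given here, only that single step bears on it, and the change is of a different kind, so for compound 3 the expected step is a number 3.9 percentage points higher from compound 2 to compound 3 (within the scatter), modest and upward at most. Compound 3 is thus estimated at 60%, within 40% to 80%.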

Compound 3, a percentage reported as inhibition, at one concentration (the size of the read-out at that concentration, not a potency): 44.4%
The estimate for compound 3 lay 15.6 percentage points above the measured number, and the stated range covers the measured number.
By their numbers in this assay, from the lowest: compounds 1 and 3 (each within the scatter of the next); then compound 2.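

In this assay, removing the amide-bearing chain altogether reverses the earlier gain, a number 11.7 percentage points lower from compound 2 to compound 3 (beyond the scatter), so shortening does not track with a higher number at this position, and compound 3 goes against any such trend. The isothiocyanate set directly on the aromatic carbon and the longest chain remain unseparated, a number 8.6 percentage points higher from compound 1 to compound 3 (within the scatter). No available evidence accounts for these differences.

Still open, from the compounds shown here alone, is whether the isothiocyanate itself matters at this position, a question that an amine or a carboxylic acid in its place would address. Going by these compounds, how a chain of other length would behave with the amide held in one orientation also remains unknown.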